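The compounds below may be only part of what the source reports. "The series", "measured", "known", "first", "only" and "open" are said of these compounds alone.

The measured compounds and their values stand as follows: compound 1 `CCCCCC(=O)Nc1ccc(S(=O)(=O)Oc2ccccc2C(C)C)cc1` gives 6400 nM; compound 2 `CC(C)c1ccccc1OS(=O)(=O)c1ccc(NC(=O)CCl)cc1` gives 5600 nM; compound 3 `O=C(CCl)Nc1ccc(S(=O)(=O)Oc2ccccc2I)cc1` gives 4100 nM, all in a functional assay on HT-29 cells (Homo sapiens) for antiproliferative activity, read by sulforhodamine B assay, with a stated time of 48 h; on this read-out higher numbers stand for weaker inhibition and lower numbers for stronger inhibition.

Compound 3 holds the lowest of the three numbers, but its distance to the others is small: the step of a 1.4-fold lower number from compound 2 to compound 3 (0.14 log units; within the scatter) and the gap to compound 1 both lie within the scatter, so no order among the three can be read from these values.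

Compound 4 `CCCCCNC(=O)Nc1ccc(S(=O)(=O)Oc2ccccc2I)cc1` differs from compound 3 in one place: pentylamino in place of chloromethyl on a carbonyl carbon. The measured step that bears on this position is a 1.1-fold lower number from compound 1 to compound 2 (0.06 log units; within the scatter), where the chain bound to the carbonyl carbon was altered without any effect beyond the scatter. Among the measured compounds shown here, the change to compound 4 is larger in size than that one, and no measured pair shows the pentylcarbamoyl arrangement, so the comparison is indirect. On the evidence of the amide-side step, the expectation is a step of a 1.2-fold higher number from compound 3 to compound 4 (0.09 log units; within the scatter) that stays within the scatter, with no clear direction.

Compound 4 is therefore expected to give about 5000 nM in this assay, with a range from 2000 nM to 15000 nM.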

Compound 4, half-maximal inhibitory concentration: 6600 nM
Estimate against measurement, compound 4: 1.3-fold (0.12 log units) below; the measured number falls inside the stated range.
By their numbers in this assay, from the lowest: compounds 3, 2, 1 and 4 (each within the scatter of the next).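

In this assay, among the compounds shown here, the step of a 1.6-fold higher number from compound 3 to compound 4 (0.21 log units; within the scatter) extends what the earlier compounds showed at this carbonyl carbon. The earlier step there changed only a substituent on the saturated chain, whereas here the whole chloromethyl group gives way to pentylamino, so the chlorine is lost and a nitrogen with one hydrogen-bond donor enters, and the difference can also be read as pentylcarbamoyl in place of (chloromethyl)carbonyl. Even this larger exchange stays within the scatter, so the assay does not separate compound 3 from compound 4, and nothing available gives a measured reason for that result.

The compounds shown leave open whether any group on this carbonyl carbon can move the number beyond the scatter, since neither of the two exchanges tried here does so. A shorter alkylamino chain, a longer chain, or a pentyl chain ending in an amine or a carboxylic acid could test this, and the same exchange with isopropyl in place of iodo on the aromatic carbon would show whether the result holds with that group.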